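Dichlorophenyl to Dimethoxyphenyl: an Expected Drop in Cytotoxicity Read-out

The source may hold more compounds than are shown below. What is called first, only, known or untested is meant among the compounds shown, and "the series" means these compounds.

Compound 1 `COc1cc(-c2cc(/C=C/C(=O)c3ccc(Cl)c(Cl)c3)[nH]n2)cc(OC)c1OC`: 16%
Compound 2 `COc1ccc(-c2cc(/C=C/C(=O)c3cc(OC)c(OC)c(OC)c3)[nH]n2)cc1OC`: -81%
Compound 3 `COc1ccc(-c2cc(/C=C/C(=O)c3ccc(N)cc3)[nH]n2)cc1`: -53%

All three were tested in a functional assay on HCT-116 cells (Homo sapiens) for cytotoxicity, read by sulforhodamine B assay, with a stated time of 48 h, tested at 10 uM; on this read-out lower numbers stand for a stronger effect and higher numbers for a weaker effect at the one concentration tested. Compound 1 stands highest of the three numbers, the weakest effect; compound 3 lies nearest, beyond the scatter below it, and compound 2 lies furthest below. Compound 4 `COc1ccc(C(=O)/C=C/c2cc(-c3cc(OC)c(OC)c(OC)c3)n[nH]2)cc1OC` is not yet measured. It differs from compound 1 in one place: 3,4-dimethoxyphenyl in place of 3,4-dichlorophenyl on a carbonyl carbon. Among the compounds with values here, no matched pair shows this change directly. The two measured compounds without chlorine, compound 2 and compound 3, both give numbers far below compound 1, so a step downward beyond the scatter is expected, a number 61 percentage points lower from compound 1 to compound 4 (beyond the scatter). Compound 4 is therefore estimated at -45% in this assay, within a range from -90% to 10%.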

Compound 4, a percentage reported as activity, at one concentration (the size of the read-out at that concentration, not a potency): -65%
The estimate for compound 4 lay 20 percentage points above the measured number; the range from low to high includes it.
By their numbers in this assay, from the lowest: compound 2; then compound 4; then compound 3; then compound 1.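

In this assay, the group on this carbonyl carbon alone shifts the read-out by a large step: with 3,4-dimethoxyphenyl in place of 3,4-dichlorophenyl, the result is a number 81 percentage points lower from compound 1 to compound 4 (beyond the scatter). Within the data shown here, the earlier compounds differed from one another in more than one place, so only this pair ties the change to this single position. Nothing shown here gives a reason for the step.

Still open, on these data alone, is how other groups at this position would read, such as a phenyl ring carrying a carboxylic acid or a trifluoromethyl. Also open, as far as these compounds go, is whether the same change would give a step of this size on a different core.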